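Dichlorophenyl in place of phenyl: expected cytotoxicity

This account rests on a few compounds, and the source may have more. Where it says the series, first, only, none or still open, it means among the compounds named here.

Compound 1, `O=C1COc2ccc(-c3[nH]c(-c4ccccc4)nc3-c3ccccc3)cc2N1`: 7.6%
Compound 2, `O=C1COc2ccc(-c3nn(-c4ccccc4)cc3-c3ccccc3)cc2N1`: 97.9%

In a functional assay on MV4-11 cells (Homo sapiens) for cytotoxicity, read by colorimetric assay and MTT assay, with a stated time of 3 days, tested at 20 uM (a higher number here means a weaker effect of the compound at the concentration tested, a lower number a stronger effect), compound 1 gives 7.6%, the lowest of the two numbers. Compound 2 gives 97.9%, a number higher by an amount well beyond the scatter, so compound 1 shows the stronger effect of the two. Compound 3, `O=C1COc2ccc(-c3[nH]c(-c4ccc(Cl)cc4Cl)nc3-c3ccccc3)cc2N1`, differs from compound 1 in one place: 2,4-dichlorophenyl in place of phenyl on an aromatic carbon. Going by the values given here, no step between two measured compounds resembles this change, so its size cannot be read from the data at hand. Since compound 1 already gives 7.6%, there is little room for a lower number, and compound 3 is expected to stay close to it, with the step of a number 7.4 percentage points higher from compound 1 to compound 3 (within the scatter) expected to be small, either none beyond the scatter or a modest rise. Compound 3 is therefore estimated at 15%, within a range from 3% to 45%.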

Compound 3, a percentage reported as activity, at one concentration (the size of the read-out at that concentration, not a potency): 41.1%
Compound 3: the middle estimate sits 26.1 percentage points below what was measured; the range from low to high includes it.
By their numbers in this assay, from the lowest: compound 1; then compound 3; then compound 2.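

In this assay, the place on the five-membered aromatic ring with 2 nitrogen, between two ring nitrogen atoms, proves sensitive to what it carries: 2,4-dichlorophenyl in place of phenyl gives a number 33.5 percentage points higher from compound 1 to compound 3 (beyond the scatter) at the single concentration tested. Going by these compounds alone, the earlier compounds offered no step of this kind, so this is the first direct reading of a change at this place, and it shows that the phenyl group cannot be swapped for this larger ring without a clear loss of effect. Nothing measured here explains why the read-out moves.

A phenyl ring carrying a single chlorine would show whether one chlorine is enough for this rise or both are needed. A phenyl ring carrying a methoxy group or an amine would show whether the rise is particular to chlorine.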